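This account rests on a few compounds, and the source may have more. Where it says the series, first, only, none or still open, it means among the compounds named here.

In an ADME assay on microsomes from liver (Rattus norvegicus) for metabolic stability (a higher number here means faster removal of the compound, a lower number slower removal), compound 1 `CNC(=O)[C@@H]1CC[C@H](c2ccc(OCc3ccccc3F)cc2)N1` gives 9.3 mL.min-1.g-1 while compound 2 `N#Cc1ccccc1COc1ccc([C@H]2CC[C@@H](C(N)=O)N2)cc1` gives 1.4 mL.min-1.g-1 and compound 3 `COc1cc([C@H]2CC[C@@H](C(N)=O)N2)ccc1OCc1ccccc1F` gives 4 mL.min-1.g-1 as the middle of the three numbers, beyond the scatter from both others. The change to compound 4 `N#Cc1cc([C@H]2CC[C@@H](C(N)=O)N2)ccc1OCc1ccccc1F` is cyano in place of methoxy on an aromatic carbon. For the measured compounds named here, no measured pair isolates this change. Going by the values given here, compound 2 is the only measured compound carrying cyano and its 1.4 mL.min-1.g-1 is the lowest number here, so a modest fall is expected, though it may stay within the scatter. The estimated step is a 1.6-fold lower number from compound 3 to compound 4 (0.20 log units; within the scatter) on this thin evidence. Compound 4 is expected at 2.5 mL.min-1.g-1 with an estimated span from 1.1 mL.min-1.g-1 to 5.5 mL.min-1.g-1 as the working range.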

Compound 4, intrinsic clearance in microsomes: 2 mL.min-1.g-1
The estimate for compound 4 lay 1.3-fold (0.10 log units) above the measured number; the measured number falls inside the stated range.
By their numbers in this assay, from the lowest: compounds 2, 4 and 3 (each within the scatter of the next, the first and the last beyond it); then compound 1.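

In this assay, for the compounds shown here, cyano in place of methoxy on an aromatic carbon, ortho to a group of 9 heavy atoms and meta to a 5-carbamoylpyrrolidin-2-yl group, gives a 2.0-fold lower number from compound 3 to compound 4 (0.30 log units; within the scatter) and is the only measured pair isolating this change. At this position the two groups therefore cannot be told apart in this read-out. Nothing measured here bears on the reason for this result. As far as these compounds go, an amine or a carboxylic acid at this position remains open. Also open, from the compounds shown here alone, is whether the change reads the same with a methyl on the amide nitrogen.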